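Extending a diamine tail by one chain carbon

A few compounds are considered here, and "the series" means these few. Any claim that something is new, unique, unknown or untested is made for them only; others in the source may bear on it.

Of the compounds shown here, three carry a shared core and have been read in a physicochemical assay, read by spectrophotometry, with a stated time of 10 min, tested at 0.08 mM, in the presence of a further agent that is not named here; on this read-out lower numbers stand for a weaker effect and higher numbers for a stronger effect at the one concentration tested. Compound 1 `CC(C)(C)OC(=O)NCC(CCCCNC(=O)CCn1cccc(O)c1=O)NC(=O)OC(C)(C)C` gives 30.2% there, and compound 2 `NCC(N)CC(=O)N1CCN(C(=O)CCn2cccc(O)c2=O)CC1` gives 27.5% in this assay. Compound 3 `NCC(N)CCCNC(=O)CCn1cccc(O)c1=O` gives 35.5% in this assay; its figure is nominally the largest of the three, yet its gaps to compound 1 and to compound 2 both fall within the usual scatter, so the three results are not separated. Compound 4 `NCC(N)CCCCNC(=O)CCn1cccc(O)c1=O` is not yet measured. It differs from compound 3 in one place: 2,3-diaminopropyl in place of 1,2-diaminoethyl on a saturated chain carbon, three bonds along the chain from an amide-type nitrogen. Within the data shown here, with no measured pair of this kind to draw on, no step beyond the scatter is expected for this assay, in either direction. Compound 4 is therefore expected to read about 34%, within 24% to 44%. The estimate implies a step of a number 1.5 percentage points lower from compound 3 to compound 4 (within the scatter).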

Compound 4, a percentage reported as activity, at one concentration (the size of the read-out at that concentration, not a potency): 34.9%
Estimate against measurement, compound 4: 0.9 percentage points below; measured number inside the range.
By their numbers in this assay, from the lowest: compounds 2, 1, 4 and 3 (each within the scatter of the next).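

In this assay, among these compounds, putting 2,3-diaminopropyl in place of 1,2-diaminoethyl on this saturated chain carbon gives a number 0.6 percentage points lower from compound 3 to compound 4 (within the scatter) and so provides the only measured pair here that differs in one place. At this position, the change of tail from 1,2-diaminoethyl to 2,3-diaminopropyl therefore leaves the read-out within the scatter. Nothing available bears on the reason for this result. Still open, going by these compounds, is whether 3,4-diaminobutyl, a longer chain carrying the same two amines, would also stay within the scatter. On these data alone, a tail ending in a single amine or a carboxylic acid also remains open.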